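A few compounds are considered here, and "the series" means these few. Any claim that something is new, unique, unknown or untested is made for them only; others in the source may bear on it.

Measured so far:
- compound 1 `O=C1/C(=C/c2ccccc2F)CN(C(=S)SCc2cn(Cc3ccccc3Cl)nn2)C/C1=C\c1ccccc1F`: 43600 nM
- compound 2 `O=C1/C(=C/c2ccccc2F)CN(C(=S)SCc2cn(Cc3ccc(F)cc3)nn2)C/C1=C\c1ccccc1F`: 9900 nM

In a functional assay on 4T1 cells (Mus musculus) for cytotoxicity, read by MTT assay, with a stated time of 24 h (a higher number here means a weaker inhibitor, a lower number a stronger inhibitor), compound 2 gives 9900 nM, the lower of the two numbers in hand. Next is compound 3 `O=C1/C(=C/c2ccccc2F)CN(C(=S)SCc2cn(Cc3cccc(Cl)c3)nn2)C/C1=C\c1ccccc1F`, which keeps the shared core: 3-chlorophenyl in place of 4-fluorophenyl on a saturated chain carbon bound to an aromatic nitrogen. That is 3-chlorophenyl in place of 4-fluorophenyl on a saturated chain carbon bound to an aromatic nitrogen.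

For the measured compounds named here, one measured step bears on this, at the same place: a 4.4-fold lower number from compound 1 to compound 2 (0.64 log units; beyond the scatter). It is modest and ran from 2-chlorophenyl to 4-fluorophenyl. Going by the values given here, no measurement yet covers 3-chlorophenyl, so that step transfers only in part. Compound 3 again carries a chlorophenyl, so a change in this assay towards a higher number is expected, smaller than the measured step. The estimated step is a 1.8-fold higher number from compound 2 to compound 3 (0.26 log units; within the scatter). For compound 3 the estimate is 18000 nM, with an expected range of 7000 nM to 45000 nM.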

Compound 3, half-maximal inhibitory concentration: > 100000 nM
Compound 3 ended at the assay's limit; the forecaster's own chance of this, stated with the estimate: 5%; middle value at least 5.5-fold (0.74 log units) from the limit.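

In this assay compound 3 gives > 100000 nM, which is a limit of the assay and not a number. The two chlorophenyl groups are not interchangeable on this saturated chain carbon bound to an aromatic nitrogen, as 3-chlorophenyl in place of 2-chlorophenyl gives an at least 2.2-fold higher number from compound 1 to compound 3 (0.36 log units; beyond the scatter). Replacing 4-fluorophenyl with 3-chlorophenyl gives an at least 10-fold higher number from compound 2 to compound 3 (1.00 log units; beyond the scatter), so a single change to this aryl group is enough to take a compound of the series to the limit of the assay.

As far as these compounds go, the true size of both steps stays open, and the second changes the halogen and its numbered ring position together. Neither 4-chlorophenyl nor 3-fluorophenyl is among the compounds shown to separate those two changes, and how an amine or a carboxylic acid on this ring would read also remains open.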